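Fused ring replaces 4-methylphenyl on the ether oxygen

The compounds below may be only part of what the source reports. "The series", "measured", "known", "first", "only" and "open" are said of these compounds alone.

Compound 1 `COc1ccccc1OC1CCN(c2ccc(-n3ccnc3)nn2)CC1`: 543 nM
Compound 2 `N#Cc1ccccc1OC1CCN(c2ccc(-n3ccnc3)nn2)CC1`: 236 nM
Compound 3 `Cc1ccc(OC2CCN(c3ccc(-n4ccnc4)nn3)CC2)cc1`: 527 nM

In an assay on microsomes from liver for inhibition of acyl-CoA desaturase 1 (Rattus norvegicus) (on this read-out higher numbers stand for weaker inhibition and lower numbers for stronger inhibition), compound 3 stands second highest of the three numbers. One step is a 1.0-fold lower number from compound 1 to compound 3 (0.01 log units; within the scatter), so those two cannot be told apart, while the other step is a 2.2-fold higher number from compound 2 to compound 3 (0.35 log units; beyond the scatter). Compound 4 `c1cc2c(c(OC3CCN(c4ccc(-n5ccnc5)nn4)CC3)c1)CCC2` is not yet measured; it differs from compound 3 by 2,3-dihydro-1H-inden-4-yl in place of 4-methylphenyl on an oxygen on a saturated carbon. Among the measured compounds shown here, the steps that bear on this change are those that swap the aryl group on the same oxygen: a 1.0-fold lower number from compound 1 to compound 3 (0.01 log units; within the scatter) and a 2.2-fold higher number from compound 2 to compound 3 (0.35 log units; beyond the scatter), one within the scatter and one modest. For the measured compounds named here, no measured step introduces the 2,3-dihydro-1H-inden-4-yl group, so compound 4 is expected to land close to compound 3, with a 1.2-fold lower number from compound 3 to compound 4 (0.07 log units; within the scatter). The estimate for compound 4 is 450 nM, ranging from 200 nM to 1000 nM.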

Compound 4, half-maximal inhibitory concentration: 10 nM
For compound 4 the middle estimate is 45-fold (1.65 log units) above the measured one; measured number below the stated range.
By their numbers in this assay, from the lowest: compound 4; then compound 2; then compounds 3 and 1 (each within the scatter of the next).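

In this assay the earlier aryl swaps on this oxygen stayed within the scatter or modest, whereas 2,3-dihydro-1H-inden-4-yl brings a large step against 4-methylphenyl (a 53-fold lower number from compound 3 to compound 4 (1.72 log units; beyond the scatter)), against 2-cyanophenyl (a 24-fold lower number from compound 2 to compound 4 (1.37 log units; beyond the scatter)) and against 2-methoxyphenyl (a 54-fold lower number from compound 1 to compound 4 (1.73 log units; beyond the scatter)). Among the compounds shown here, this position can therefore move the number much further than the earlier compounds showed, with a five-membered non-aromatic ring of carbon only entering and the hydrogen-bond donor and acceptor counts unchanged. Nothing at hand explains the gain. On these data alone, whether a naphthyl group would match it, or a hydroxyl on the five-membered ring would keep it, stays open.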